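A few compounds are considered here, and "the series" means these few. Any claim that something is new, unique, unknown or untested is made for them only; others in the source may bear on it.

Compound 1 `CO[C@]1(c2cc(F)cc(S(=O)(=O)c3ccc(/C(C)=N/OCC#N)cc3)c2)CCO[C@@H](C)C1`: 60 nM
Compound 2 `COC1(c2csc(Sc3ccc4c(c3)CC/C4=N\O)c2)CCOCC1`: 130 nM

In a functional assay (blood) for inhibition, with Homo sapiens as the target (a higher number here means a weaker inhibitor, a lower number a stronger inhibitor), compound 2 gives 130 nM, the higher of the two numbers, while compound 1 gives 60 nM, a gap beyond the usual scatter. The two compounds differ in more than one place, so their values simply stand side by side. Compound 3 `COC1(c2csc(Sc3ccc4c(c3)CC/C4=N\OCC#N)c2)CCOCC1` has not yet been measured. It differs from compound 2 in one place: cyanomethyl in place of hydrogen on an oxygen, so hydroxy becomes cyanomethoxy. Compound 1 carries the same cyanomethoxy on a different core, which offers only a faint hint. A small step toward a lower number is expected, a 1.6-fold lower number from compound 2 to compound 3 (0.21 log units; within the scatter). Compound 3 is estimated at 80 nM, with a range from 30 nM to 250 nM.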

Compound 3, half-maximal inhibitory concentration: 40 nM
Compound 3: the middle estimate sits 2.0-fold (0.30 log units) above what was measured; the measured number falls inside the stated range.
By their numbers in this assay, from the lowest: compounds 3 and 1 (each within the scatter of the next); then compound 2.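

On the oxygen whose other neighbour is a double-bonded nitrogen, replacing hydroxy with cyanomethoxy on the shared core gives a 3.3-fold lower number from compound 2 to compound 3 (0.51 log units; beyond the scatter) in this assay. For the compounds shown here, compounds 1 and 2 differ in more than one place, so only this pair isolates the change, and it shows that the hydrogen on this oxygen is not needed for inhibition here. Nothing measured here explains the size of this step.

Whether the nitrile matters remains open, since a plain methyl or ethyl group on this oxygen is not among the compounds shown. How a longer chain, an amine or a carboxylic acid would behave at this position is also unknown.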